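The source may hold more compounds than are shown below. What is called first, only, known or untested is meant among the compounds shown, and "the series" means these compounds.

Series notes on the shared core. Compound 1 `CC1(C)CN(c2cccnc2)C(=O)c2ccc(Cl)cc21` gives 1540 nM in an assay on cells for inhibition of cytochrome P450 11B2, mitochondrial (Homo sapiens), read by HTRF; a higher number here means a weaker inhibitor, a lower number a stronger inhibitor. Compound 2 `CC1CN(c2cccnc2)C(=O)c2ccc(Cl)cc21` differs from it by hydrogen in place of methyl on a saturated ring carbon and gives 164 nM in this assay; the step is a 9.4-fold lower number from compound 1 to compound 2 (0.97 log units; beyond the scatter). Compound 3 `CC(=O)N[C@@H]1CCCc2c1cncc2N1C(=O)c2ccc(Cl)cc2[C@H]1C` is built on a second core; the difference between the two cores is not broken down here. In this assay compound 3 gives 130 nM, which lies within the scatter of compound 2.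

Compound 4 `CC(=O)N[C@@H]1CCCc2c1cncc2N1Cc2cc(Cl)ccc2C1=O` is not yet measured. From compound 3 it differs by hydrogen in place of methyl on a saturated ring carbon. This is the same kind of change as from compound 1 to compound 2, not the same: there the place was on a saturated ring carbon of a six-membered non-aromatic ring with 1 nitrogen, two ring bonds from the ring nitrogen and two ring bonds from the ring atom that bears a pyridin-3-yl group; here it is on a five-membered non-aromatic ring with 1 nitrogen, next to the ring nitrogen and next to the ring atom that bears a large group.

From the step of a 9.4-fold lower number from compound 1 to compound 2 (0.97 log units; beyond the scatter) a lower number is expected for compound 4, a step of about a 2.9-fold lower number from compound 3 to compound 4 (0.46 log units; beyond the scatter), taken smaller than that earlier one since the ring and its surroundings are not the same. Compound 4 is estimated at 45 nM, between 12 nM and 150 nM.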

Compound 4, half-maximal inhibitory concentration: 44 nM
Estimate against measurement, compound 4: 1.0-fold (0.01 log units) above; the range from low to high includes it.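

In this assay, hydrogen in place of methyl on a saturated ring carbon gives a 3.0-fold lower number from compound 3 to compound 4 (0.47 log units; beyond the scatter) on the second core, so the direction of the change carries over between the two cores shown. The size of the change does not carry over: the same change on two cores in this assay, a 9.4-fold lower number (0.97 log units; beyond the scatter) from compound 1 to compound 2 and a 3.0-fold lower number (0.47 log units; beyond the scatter) from compound 3 to compound 4, 3.2-fold (0.50 log units) apart, beyond the scatter of two such steps. The two pairs differ in both the core and the ring that carries the change, so they do not show which of these differences sets the size, and two pairs give no rule for any further core in the series.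

The compounds shown compare only methyl and hydrogen at this ring carbon, which leaves open how a hydroxyl group, a fluorine atom or a longer chain there would compare. Also open, on these data alone, is whether the same change would keep its direction if the acetamide of compound 3 and compound 4 were replaced by an amine or a carboxylic acid.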